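A few compounds are considered here, and "the series" means these few. Any claim that something is new, unique, unknown or untested is made for them only; others in the source may bear on it.

Measured compounds in the series:

Compound 1 `CCOC(=O)c1sc(-c2ccccc2)nc1CO` — in an assay on HEK293 cells for inhibition of transient receptor potential cation channel subfamily M member 8 (Homo sapiens), read by FLIPR, with stated times of 5 min and 3 min (a higher number here means a weaker inhibitor, a lower number a stronger inhibitor), compound 1 gives > 100000 nM, which is a limit of the assay rather than a number (the limit of > 100000 nM in this assay, at which 1 of the 2 values shown sits).
Compound 2 `CCOC(=O)c1sc(-c2ccccc2)nc1O` — in this assay compound 2 gives 32 nM.

For the measured compounds named here, compound 2 therefore holds the only actual number in this assay; the other entry is a limit. Going by the values given here, the single measured step, an at least 3100-fold lower number from compound 1 to compound 2 (3.49 log units; beyond the scatter), shows that the group on this ring carbon decides the read-out: hydroxy in place of hydroxymethyl moved the value from the limit down to the number of compound 2.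

Compound 3 `CCOC(=O)c1sc(-c2ccccc2)nc1NC(=O)C(F)(F)F` is the next compound and carries the change (((trifluoromethyl)carbonyl)amino in place of hydroxy on an aromatic carbon). The group enters on an aromatic carbon of the five-membered ring, next to the ring nitrogen and next to the ring atom that bears the ethoxycarbonyl group. Among the compounds with values here, the only step that bears on it is the one from compound 1 to compound 2, which was large and shows how much the hydroxy contributes; compound 3 gives that hydroxy up for a considerably larger group. A step back towards weaker inhibition in this assay is expected, most likely a large one, though the trifluoroacetamide keeps a donor and an acceptor, so it need not reach the limit. Compound 3 is estimated at 1500 nM, range 100 nM to 40000 nM, a step of a 47-fold higher number from compound 2 to compound 3 (1.67 log units; beyond the scatter) expected.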

Compound 3, half-maximal inhibitory concentration: 7700 nM
Estimate against measurement, compound 3: 5.1-fold (0.71 log units) below; measured number inside the range.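

With a 240-fold higher number from compound 2 to compound 3 (2.38 log units; beyond the scatter), the ((trifluoromethyl)carbonyl)amino group on this aromatic carbon next to the ring nitrogen does not keep the read-out that the hydroxy gives in this assay, although the computed counts of hydrogen-bond donors and acceptors are the same for the two groups, so these counts alone do not settle the value at this position. For the compounds shown here, the hydroxy is nevertheless not the only group here that gives a measured number, since an at least 12-fold lower number from compound 1 to compound 3 (1.11 log units; beyond the scatter) sets the ((trifluoromethyl)carbonyl)amino group apart from hydroxymethyl at the same carbon. Compound 1 remains the one entry that is a limit and not a number: the limit of > 100000 nM in this assay, at which 1 of the 3 values shown sits.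

The compounds shown leave open which part of the ((trifluoromethyl)carbonyl)amino group goes with the higher number, and a plain amino group or an acetylamino group on this carbon would bear on that. They also leave open whether the read-out at this position depends on the ethoxycarbonyl group on the neighbouring ring atom, which a carboxylic acid or a primary amide in its place would test.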